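The source may report more compounds than this note shows. Statements on the series, on what has been measured and on what is new or still open speak of the compounds shown alone.

Measured compounds:
Compound 1, `CCSC1=N[C@@H](C(=O)OC)[C@@H]2C(=O)N(c3ccccc3)C(=O)[C@H]12`, gives 91%.
Compound 2, `CCCCSC1=N[C@H](C(=O)OC)[C@@H]2C(=O)N(c3ccccc3)C(=O)[C@H]12`, gives 89%.

Both numbers come from a functional assay for inhibition, tested at 100 uM; a lower number here means less inhibition, a higher number more inhibition at the concentration tested (going by the name of the read-out). On those two numbers compound 2 stands lowest, and its nearest neighbour is compound 1, whose reading is higher by a gap that lies within the usual scatter of repeated measurements. The two compounds therefore cannot be told apart on this evidence, and the inhibition in this assay is level between them.

The step now followed leads from compound 2 to compound 3, `CCCCSC1=N[C@@H](C(=O)OC)[C@@H]2C(=O)N(c3ccccc3)C(=O)[C@H]12`, which is still to be measured in this assay. the two compounds have the same atoms and bonds and differ only in configuration as drawn: 1 of 3 stereo elements differ; a stereocentre at a saturated ring carbon is drawn S in compound 2 and R in compound 3 No other part of the molecule changes.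

For the measured compounds named here, because compound 2 gives 89% and compound 1 gives 91%, the data so far show only high readings, and no step between measured compounds is available to calibrate how much a single configuration change can move the number. The expectation is therefore a step from compound 2 to compound 3 of no change at the digits printed from compound 2 to compound 3 (within the scatter), most likely none beyond the scatter. Compound 3 is estimated to give 89%, with a plausible range from 74% to 96%.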

Compound 3, a percentage reported as inhibition, at one concentration (the size of the read-out at that concentration, not a potency): 82%
Compound 3: the middle estimate sits 7 percentage points above what was measured, and the stated range covers the measured number.
By their numbers in this assay, from the lowest: compounds 3, 2 and 1 (each within the scatter of the next).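

In this assay, changing the drawn configuration at one saturated ring carbon gives a number 7 percentage points lower from compound 2 to compound 3 (within the scatter), so this stereocentre can be inverted with no shift that stands clear of the scatter. This pair isolates that single stereocentre, and any gap between the two readings can be traced to nothing else: the fact that compounds 2 and 3 differ only in the configuration as drawn

The second step, with ethyl in place of hydrogen on a saturated chain carbon, two bonds along the chain from a sulfur, gives a number 9 percentage points lower from compound 1 to compound 3 (within the scatter), so at this configuration the chain can also be lengthened with no change that can be told from the scatter.

All of these readings come from one concentration, so they give no potency, and differences among the compounds could be hidden at so high a test level. Still open, going by these compounds, are whether an amine on the chain, or a carboxylic acid in place of the methyl ester, would move the number beyond the scatter, and whether the other two stereo elements matter.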